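The compounds below may be only part of what the source reports. "The series", "measured", "known", "first", "only" and "open" are said of these compounds alone.

Of the compounds shown here, two built on a shared core have been measured so far. Compound 1 `COc1ccc(NC(=O)[C@@H]2Cc3ccc(OCC(=O)NO)cc3CN2C(=O)CNC(=O)OC(C)(C)C)cc1` gives 514 nM in an assay on isolated protein for inhibition of histone deacetylase 8 (Homo sapiens), read by fluorescence, with a stated time of 30 min; a lower number here means a stronger inhibitor, a higher number a weaker inhibitor. Compound 2 `COc1ccc(NC(=O)[C@@H]2Cc3ccc(OCC(=O)NO)cc3CN2C(=O)[C@@H]2CCCN2)cc1`, which carries pyrrolidin-2-yl in place of ((tert-butoxycarbonyl)amino)methyl on a carbonyl carbon, gives 481 nM in this assay. The step of a 1.1-fold lower number from compound 1 to compound 2 (0.03 log units; within the scatter) lies within the scatter, so the two numbers cannot be told apart. Compound 2 thus holds the lower of the two numbers, with compound 1 nearest, but the gap between them says nothing firm.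

Compound 3 `CC[C@H](C)[C@H](N)C(=O)N1Cc2cc(OCC(=O)NO)ccc2C[C@H]1C(=O)Nc1ccc(OC)cc1` has not yet been measured. It differs from compound 2 by 1-amino-2-methylbutyl in place of pyrrolidin-2-yl on a carbonyl carbon. Going by the values given here, only one measured step touches the same carbonyl carbon, namely a 1.1-fold lower number from compound 1 to compound 2 (0.03 log units; within the scatter), where exchanging the group at this position left the number essentially unchanged. Among the compounds with values here, on that single precedent, no step in this assay beyond the scatter is expected from compound 2 to compound 3 in either direction. Compound 3 is therefore estimated at 450 nM, within a range from 200 nM to 1100 nM, and the expected step of a 1.1-fold lower number from compound 2 to compound 3 (0.03 log units; within the scatter) should stay within the scatter.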

Compound 3, half-maximal inhibitory concentration: 1040 nM
Estimate against measurement, compound 3: 2.3-fold (0.36 log units) below; measured number inside the range.
By their numbers in this assay, from the lowest: compounds 2 and 1 (each within the scatter of the next); then compound 3.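

The carbonyl carbon bonded to the ring amide-type nitrogen is not indifferent to the group it carries. In this assay, going by these compounds alone, replacing pyrrolidin-2-yl with 1-amino-2-methylbutyl gives a 2.2-fold higher number from compound 2 to compound 3 (0.33 log units; beyond the scatter) and replacing ((tert-butoxycarbonyl)amino)methyl with the same group gives a 2.0-fold higher number from compound 1 to compound 3 (0.31 log units; beyond the scatter), so these are the first changes at this position that can be told apart from the scatter, though both are modest, and compound 3 is the weakest of the three while compound 1 and compound 2 cannot be separated. No accompanying measurement accounts for the higher number of compound 3.

The entering group differs from pyrrolidin-2-yl at once in having no ring, in having one more heavy atom and in having a second defined stereocentre, and these three compounds cannot show which of these differences matters, if any does. A plain aminomethyl group or a piperidin-2-yl ring on the same carbonyl carbon would help to separate the question of the ring from that of the size of the group.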